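The compounds below may be only part of what the source reports. "The series", "measured", "known", "first", "only" and "open" are said of these compounds alone.

In a functional assay on PC-3 cells (Homo sapiens) for inhibition, with a stated time of 72 h (on this read-out higher numbers stand for weaker inhibition and lower numbers for stronger inhibition), compound 1 `COc1ccc(NC(=O)Nc2nc(Sc3c[nH]c4ccccc34)cc(N3CCCCC3)n2)cc1` gives 17400 nM, while compound 3 `O=C(Nc1ccc(Cl)cc1)Nc1nc(Sc2c[nH]c3ccccc23)cc(N2CCCCC2)n1` gives 42500 nM, the higher of the two numbers. The gap between them is a 2.4-fold higher number from compound 1 to compound 3 (0.39 log units; beyond the scatter). Compound 2 `Cc1ccc(C)c(NC(=O)Nc2nc(Sc3c[nH]c4ccccc34)cc(N3CCCCC3)n2)c1` is reported only as a limit, > 50000 nM. Compound 4 `O=C(Nc1ccccc1)Nc1nc(Sc2c[nH]c3ccccc23)cc(N2CCCCC2)n1` differs from compound 3 by hydrogen in place of chloro on an aromatic carbon. For the measured compounds named here, no measured step makes this exact exchange. The closest evidence is the modest replacement of methoxy by chloro already noted, together with an at least 1.1-fold lower number from compound 2 to compound 3 (0.07 log units; that floor lies within the scatter), whose floor lies within the scatter. No step beyond the scatter is therefore expected in this assay. The step expected is a 1.4-fold lower number from compound 3 to compound 4 (0.15 log units; within the scatter). Compound 4 is estimated at 30000 nM, with an expected range of 12000 nM to 50000 nM.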

Compound 4, half-maximal inhibitory concentration: 12100 nM
Estimate against measurement, compound 4: 2.5-fold (0.39 log units) above; low and high end bracket the measured number.
By their numbers in this assay, from the lowest: compounds 4 and 1 (each within the scatter of the next); then compound 3. At a limit, above all of these: compound 2.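

In this assay, taking the chloro off the 4-chlorophenyl group matters beyond the scatter, with a 3.5-fold lower number from compound 3 to compound 4 (0.55 log units; beyond the scatter). Hydrogen and methoxy at this place cannot be told apart, with a 1.4-fold lower number from compound 1 to compound 4 (0.16 log units; within the scatter), so among these three compounds chloro alone stands apart. The phenyl compound also separates from the 2,5-dimethylphenyl compound, with an at least 4.1-fold lower number from compound 2 to compound 4 (0.61 log units; beyond the scatter), but compound 2 is reported only as a limit, so this step is a floor: the limit of > 50000 nM in this assay, at which 1 of the 4 values shown sits.

The compounds shown leave open whether fluoro, hydroxy or an amine at this place would follow hydrogen and methoxy or would follow chloro. They also leave open how a single methyl there would compare.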